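Swapping the Halogenated Phenyl on the Shared Core

A few compounds are considered here, and "the series" means these few. Any claim that something is new, unique, unknown or untested is made for them only; others in the source may bear on it.

Compound 1 `CCCNC(=O)c1cc(Oc2ccc(NC(=O)c3cc4cccnc4n(-c4ccccc4)c3=O)cc2)ccn1` gives 110 nM in a functional assay on NCI-H460 cells (Homo sapiens) for antiproliferative activity, read by MTT assay, with a stated time of 72 h; on this read-out higher numbers stand for weaker inhibition and lower numbers for stronger inhibition.
Compound 2 `CCCNC(=O)c1cc(Oc2ccc(NC(=O)c3cc4cccnc4n(-c4ccc(Br)cc4)c3=O)cc2)ccn1` gives 620 nM in this assay.

Compound 2 stands as the higher of the two numbers in this assay. Compound 3 `CCCNC(=O)c1cc(Oc2ccc(NC(=O)c3cc4cccnc4n(-c4ccc(F)c(Cl)c4)c3=O)cc2)ccn1` differs from it by 3-chloro-4-fluorophenyl in place of 4-bromophenyl on an aromatic nitrogen. Within the data shown here, the only step on record is a 5.6-fold higher number from compound 1 to compound 2 (0.75 log units; beyond the scatter), where a halogen joined the phenyl on the aromatic nitrogen. Compound 3 keeps a halogen-bearing phenyl at that same place, so a number close to compound 2 is expected, and the step of a 1.2-fold lower number from compound 2 to compound 3 (0.09 log units; within the scatter) is estimated to stay within the scatter. For compound 3 the expected value in this assay is 500 nM, between 200 nM and 1500 nM.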

Compound 3, half-maximal inhibitory concentration: 1600 nM
The estimate for compound 3 lay 3.2-fold (0.51 log units) below the measured number, outside the stated range (above it).
By their numbers in this assay, from the lowest: compound 1; then compound 2; then compound 3.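

In this assay halogenated phenyls at this place are not interchangeable: 3-chloro-4-fluorophenyl in place of 4-bromophenyl gives a 2.6-fold higher number from compound 2 to compound 3 (0.41 log units; beyond the scatter) and so the mere presence of a halogen does not fix the number. Against the plain phenyl, the same group gives a 15-fold higher number from compound 1 to compound 3 (1.16 log units; beyond the scatter) and this is the largest step on record at this position. No available evidence explains these shifts.

The compounds shown leave open whether a lone fluorine or chlorine on the phenyl would fall nearer compound 1 or compound 3. As far as these compounds go, how a methoxy group or an amine there would compare also remains open.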